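Step from compound 3 to compound 4

A few compounds are considered here, and "the series" means these few. Any claim that something is new, unique, unknown or untested is made for them only; others in the source may bear on it.

In a functional assay on the whole organism with Mus musculus as the target (on this read-out lower numbers stand for an effect already at smaller amounts and higher numbers for an effect only at larger amounts of compound), compound 1 `O=C1CCC(O)(c2cccc(C(F)(F)F)c2)N1` gives > 200 mg/kg, which is a limit and not a number. Compound 2 `CCN1C(=O)CCC1(O)c1cccc(C(F)(F)F)c1` gives > 100 mg/kg, also a limit. Compound 3 `CN(C)C(=O)CCC(=O)c1cccc(C(F)(F)F)c1` gives > 50 mg/kg, again a limit. Among the compounds with values here, compound 3 therefore has no numerical position, and no measured compound offers a number to compare it with.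

Compound 4 `CC(C)CNC(=O)CCC(=O)c1cccc(C(F)(F)F)c1` differs from compound 3 by isobutylamino in place of dimethylamino on a carbonyl carbon. Within the data shown here, the only measured step is a step that the two limits leave unreadable from compound 1 to compound 2. It concerns an amide-type nitrogen in a ring, its size cannot be read, and it lends no size to the change at the carbonyl carbon. Among the measured compounds shown here, no measured step therefore sets a size or direction in this assay, and the expectation rests on the limits alone. The expected change is a step that the limit leaves unreadable from compound 3 to compound 4, a loosely estimated step. Compound 4 is expected at 90 mg/kg, with an estimated range of 30 mg/kg to 270 mg/kg.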

Compound 4, dose for half-maximal effect: > 200 mg/kg
Compound 4: no number, only a limit; the forecaster's own chance of this, stated with the estimate: 60%; middle value at least 2.2-fold (0.34 log units) from the limit.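

Compound 3 and compound 4 both stand as limits in this assay, so the step from dimethylamino to isobutylamino on the carbonyl carbon cannot be read. The compounds shown leave open at what dose any of them reaches half-maximal effect, and which of these two groups gives the lower dose.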